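The compounds below may be only part of what the source reports. "The series", "measured", "known", "first", "only" and "open" are said of these compounds alone.

Compound 3 `CSc1ccc(-c2c(C)nc3c(N4CC[C@@H](NC(C)=O)C4)cc(C)nn23)cc1` stands at the upper limit of an ADME assay on microsomes from liver (Homo sapiens) for metabolic stability, read by LC-MS, with NADPH named in the record, with a stated time of 60 min, tested at 1 uM, in the absence of a further agent; on this read-out lower numbers stand for a less stable compound and higher numbers for a more stable compound: in this assay compound 3 gives > 95%, which is a limit of the assay and not a number. Compound 1 `CC(=O)N[C@@H]1CCN(c2cc(C)nn3c(-c4ccc(C#N)cc4)c(C)nc23)C1` also gives > 95% in this assay, again a limit. Compound 2 `COc1cc(-c2c(C)nc3c(N4CC[C@@H](NC(C)=O)C4)cc(C)nn23)ccc1F` gives > 95% in this assay, once more a limit. All three values sit at the limit of > 95% in this assay, at which 3 of the 3 values shown sit, so the steps a step that the two limits leave unreadable from compound 1 to compound 2, a step that the two limits leave unreadable from compound 1 to compound 3 and a step that the two limits leave unreadable from compound 2 to compound 3 cannot be sized. The unmeasured compound 4 `CC(=O)N[C@@H]1CCN(c2cc(C)nn3c(-c4ccco4)c(C)nc23)C1` differs from compound 3 by furan-2-yl in place of 4-(methylsulfanyl)phenyl on an aromatic carbon. For the measured compounds named here, no measured step involves a furan-2-yl, and none has a readable size, so the expected step is a number at least 3 percentage points lower from compound 3 to compound 4 (that floor lies within the scatter), none beyond the scatter. Compound 4 is therefore estimated at 92%, between 78% and 99%.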

Compound 4, percent of the compound remaining: > 95%
Compound 4 ended at the assay's limit; the forecaster's own chance of this, stated with the estimate: 60%; middle value at least 3 percentage points from the limit.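

Compound 4 sits at the same limit as compound 1, compound 2 and compound 3 in this assay, so none of its steps to these three compounds can be read: the limit of > 95% in this assay, at which 4 of the 4 values shown sit. On these data alone, how far apart the four compounds truly lie, and whether any group at this place on the shared core would leave less compound remaining, stays open.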